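The compounds below may be only part of what the source reports. "The series", "measured", "known", "first", "only" and "open" are said of these compounds alone.

Series notes. Compound 1 `O=C(Nc1cc(C(F)(F)F)cc(C(F)(F)F)c1)c1cc(Cl)c(-c2ccccc2)cc1O` gives 560 nM in a functional assay on NALM-6 cells (Homo sapiens) for cytotoxicity, read by luminescence and CellTiter-Glo, with a stated time of 3 days; a lower number here means a stronger inhibitor, a higher number a weaker inhibitor. Compound 2 `O=C(Nc1ccc(C(F)(F)F)cc1)c1cc(Cl)c(-c2ccccc2)cc1O` gives 800 nM in this assay, and compound 3 `O=C(Nc1cc(F)cc(F)c1)c1ccc2cccnc2c1O` gives 310 nM. Both sit within the scatter of compound 1, so no ranking among the three can be read; compound 1 simply stands second highest of the three numbers, with compound 2 nearest and compound 3 furthest. Compound 4 `O=C(Nc1cc(C(F)(F)F)cc(C(F)(F)F)c1)c1cc(Br)c(-c2ccccc2)cc1O` differs from compound 1 in one place: bromo in place of chloro on an aromatic carbon. For the measured compounds named here, no measured pair carries this change, so its size is not fixed by the data. The expected step is a 1.2-fold lower number from compound 1 to compound 4 (0.09 log units; within the scatter), none beyond the scatter. Compound 4 is estimated at 450 nM in this assay, with a range from 200 nM to 1100 nM.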

Compound 4, half-maximal inhibitory concentration: 840 nM
For compound 4 the middle estimate is 1.9-fold (0.27 log units) below the measured one; measured number inside the range.
By their numbers in this assay, from the lowest: compounds 3, 1, 2 and 4 (each within the scatter of the next, the first and the last beyond it).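

In this assay, the pair gives the first measured size for this change: a 1.5-fold higher number from compound 1 to compound 4 (0.18 log units; within the scatter). On this aromatic carbon, ortho to a phenyl group and para to a hydroxy group, bromo in place of chloro therefore gives no readable shift in the number. Nothing available bears on why the step is this size.

Compounds 1, 2 and 4 carry only chloro or bromo at this position. As far as these compounds go, whether a methyl, a nitrile or an amine here would move the number beyond the scatter remains open.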